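Removing the chloro from compound 2

The compounds below may be only part of what the source reports. "The series", "measured", "known", "first", "only" and "open" are said of these compounds alone.

Values in an ADME assay on MT4 cells (Homo sapiens) for cytotoxicity; a higher number here means that more compound is tolerated, a lower number that less compound is tolerated:
- compound 1 `O=C(NC(=S)Nc1cccc(C(F)(F)F)c1)c1ccccc1`: > 100000 nM (a limit of the assay)
- compound 2 `FC(F)(F)c1cccc(NC(=S)Nc2ccc(Cl)cc2)c1`: 6800 nM
- compound 3 `CCCCc1ccc(NC(=S)Nc2cccc(C(F)(F)F)c2)c(C)c1`: 43000 nM

Of the two actual numbers, compound 2 at 6800 nM is the lower, and compound 3 at 43000 nM stands higher, a gap beyond the scatter. Next comes compound 4 `FC(F)(F)c1cccc(NC(=S)Nc2ccccc2)c1`, with hydrogen in place of chloro on an aromatic carbon, para to a large group: hydrogen in place of chloro on an aromatic carbon. Within the data shown here, no measured pair isolates this change, so the expectation is loose. Among the measured compounds shown here, a moderate move to a higher number, beyond the scatter, is expected in this assay, since compound 2 at 6800 nM holds the lowest number so far. The estimated step is a 2.9-fold higher number from compound 2 to compound 4 (0.47 log units; beyond the scatter). For compound 4 the estimated value is 20000 nM, with an expected range of 6000 nM to 70000 nM.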

Compound 4, half-maximal cytotoxic concentration: 39000 nM
Compound 4: the middle estimate sits 2.0-fold (0.29 log units) below what was measured; low and high end bracket the measured number.
By their numbers in this assay, from the lowest: compound 2; then compounds 4 and 3 (each within the scatter of the next). At a limit, above all of these: compound 1.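

In this assay, among these compounds, the 4-chlorophenyl to phenyl change gives the first pair that differs in one place only (a 5.7-fold higher number from compound 2 to compound 4 (0.76 log units; beyond the scatter)). With only this position differing, the lower number of compound 2 goes with the chloro, a modest step but beyond the scatter. Compound 1 alone stands at a limit of the assay: the limit of > 100000 nM in this assay, at which 1 of the 4 values shown sits.

As far as these compounds go, whether fluoro, methyl or methoxy at this position reads like chloro or like hydrogen stays open. So does whether an amine or a carboxylic acid here would move the number at all.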